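The compounds below may be only part of what the source reports. "The series", "measured", "known", "first", "only" and "open" are said of these compounds alone.

Compound 1 `O=c1c(Cl)c(CSC(=S)N2CCCCC2)oc2ccccc12` in a functional assay on MCF7 cells (Homo sapiens) for antiproliferative activity, read by MTT assay, with a stated time of 72 h; on this read-out higher numbers stand for weaker inhibition and lower numbers for stronger inhibition: 1000 nM.
Compound 2 `CC(C)N(C(=S)SCc1oc2ccccc2c(=O)c1Cl)C(C)C` in this assay: > 40000 nM, a limit of the assay and not a number.
Compound 3 `CC(C)N(C(=S)SCc1cc(=O)c2ccc(Cl)cc2o1)C(C)C` in this assay: > 25000 nM, likewise a limit.

Compound 2 stands at a limit of this assay, so no number for it is known. One of the other two values is also a limit (the limit of > 25000 nM in this assay, at which 1 of the 3 values shown sits), and the limit at which compound 2 sits the limit of > 40000 nM in this assay, at which 1 of the 3 values shown sits, is the higher of the two. Compound 4 `O=c1c(Cl)c(CSC(=S)N2CCOCC2)oc2ccccc12` arises from compound 2 by morpholin-4-yl in place of diisopropylamino on a thiocarbonyl carbon. Among the measured compounds shown here, the one measured step that bears on this change is an at least 40-fold higher number from compound 1 to compound 2 (1.60 log units; beyond the scatter); that step runs from piperidin-1-yl to the open diisopropylamino group, and the change to compound 4 runs from diisopropylamino back to a ring amine, morpholin-4-yl. The step in this assay from compound 2 to compound 4 is therefore expected to be large and towards a lower number. For the measured compounds named here, whether it reaches the level of compound 1 the data do not settle, as no morpholin-4-yl analogue has been measured and compound 2 is only a limit. Compound 4 is estimated at 4000 nM, within 1000 nM to 20000 nM, which means an expected at least 10-fold lower number from compound 2 to compound 4 (1.00 log units; beyond the scatter).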

Compound 4, half-maximal inhibitory concentration: 11100 nM
For compound 4 the middle estimate is 2.8-fold (0.44 log units) below the measured one; measured number inside the range.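

In this assay, a ring amine on the thiocarbonyl carbon does not by itself return the series to its best level, as the two ring amines shown are separated by a clear gap: an 11-fold higher number from compound 1 to compound 4 (1.05 log units; beyond the scatter). Morpholin-4-yl still gives a measured number where diisopropylamino does not, with an at least 3.6-fold lower number from compound 2 to compound 4 (0.55 log units; beyond the scatter), so activity at this place depends on which amine is attached and not only on whether it is closed into a ring. Compound 2 stands at a limit of the assay, so the size of that step remains a lower bound: the limit of > 40000 nM in this assay, at which 1 of the 4 values shown sits.

What the compounds shown leave open is whether the oxygen of morpholin-4-yl is what separates it from piperidin-1-yl, or whether any other ring atom at that point in the ring would give a similar step; a piperazin-1-yl or a 4-methylpiperidin-1-yl group on the same thiocarbonyl carbon would address this. Also open, on these data alone, is how ring size and small open amines rank here, for which pyrrolidin-1-yl, azepan-1-yl and dimethylamino would be the matching groups.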